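Swapping the Amine Ring on a Dithiocarbamate Chromone

A few compounds are considered here, and "the series" means these few. Any claim that something is new, unique, unknown or untested is made for them only; others in the source may bear on it.

Compound 1 `COc1ccc2occ(CSC(=S)N3CCCCC3)c(=O)c2c1` was tested in a functional assay on SW480 cells (Homo sapiens) for antiproliferative activity, read by MTT assay, with a stated time of 72 h (a lower number here means a stronger inhibitor, a higher number a weaker inhibitor), and gives 6700 nM. Among the three measured compounds it stands second highest: compound 2 `O=c1cc(CSC(=S)N2CCCCC2)oc2cc(Cl)ccc12` gives 2500 nM, a lower number lying beyond the usual scatter, while compound 3 `CC(C)N(C(=S)SCc1oc2ccccc2c(=O)c1Cl)C(C)C` gives 18100 nM, a higher number also beyond the scatter. Compound 4 `COc1ccc2occ(CSC(=S)N3CCOCC3)c(=O)c2c1` has not yet been measured. It differs from compound 1 in one place: morpholin-4-yl in place of piperidin-1-yl on a thiocarbonyl carbon. Within the data shown here, no measured pair shows this particular change, so its effect is unknown. The step of a 1.2-fold higher number from compound 1 to compound 4 (0.08 log units; within the scatter) is expected to be small, most likely within the scatter, with a slight lean toward a higher number. Compound 4 is therefore estimated at 8000 nM, with a range from 3000 nM to 25000 nM.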

Compound 4, half-maximal inhibitory concentration: 7100 nM
Beside the measured number, compound 4's estimate is 1.1-fold (0.05 log units) above it; the measured number falls inside the stated range.
By their numbers in this assay, from the lowest: compound 2; then compounds 1 and 4 (each within the scatter of the next); then compound 3.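

Placing morpholin-4-yl in place of piperidin-1-yl on the thiocarbonyl carbon gives a 1.1-fold higher number from compound 1 to compound 4 (0.03 log units; within the scatter) in this assay. On this core, then, a ring with one more hetero atom and one hydrogen-bond acceptor reads the same as the original ring within normal assay variation. Nothing measured here speaks to why the two rings read alike. As far as these compounds go, whether a piperazin-1-yl ring or a dimethylamino group at this place would also read alike remains open, as does whether this swap behaves the same way on the core of compound 2.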